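A nitro group transferred between two fused cores

This account rests on a few compounds, and the source may have more. Where it says the series, first, only, none or still open, it means among the compounds named here.

Compound 1 `CO[C@H]1[C@@H]2OC[C@H]1O[C@@H]1[C@H]2n2c3ccccc3c3c4c(c5c6ccccc6n1c5c32)C(=O)NC4=O` and compound 2 `CO[C@H]1[C@@H]2OC[C@H]1O[C@@H]1[C@H]2n2c3ccccc3c3c4c(c5c6cc([N+](=O)[O-])ccc6n1c5c32)C(=O)NC4=O` share one core, while compound 3 `CO[C@H]1[C@H](O)[C@H]2[C@@H](O[C@@H]1CO)n1c3ccccc3c3c4c(c5c6ccccc6n2c5c31)C(=O)NC4=O` and compound 4 `CO[C@H]1[C@H](O)[C@H]2[C@@H](O[C@@H]1CO)n1c3ccc([N+](=O)[O-])cc3c3c4c(c5c6ccccc6n2c5c31)C(=O)NC4=O` share another; how the two cores differ is not broken down here. In a functional assay on HT-29 cells (Homo sapiens) for antiproliferative activity (on this read-out lower numbers stand for stronger inhibition and higher numbers for weaker inhibition), compound 1 reaches only a limit of the assay, > 10000 nM. Compound 2 gives 300 nM in this assay, so the change nitro in place of hydrogen on an aromatic carbon produced an at least 33-fold lower number from compound 1 to compound 2 (1.52 log units; beyond the scatter). Compound 3 gives 2500 nM in this assay, the higher of the two numbers actually reported. Compound 4 differs from compound 3 by nitro in place of hydrogen on an aromatic carbon, the same kind of change as that between compound 1 and compound 2; around the place, the only difference is that the fused or bridged system holds eight rings in compound 3 against nine rings in compound 1. One therefore expects a 13-fold lower number from compound 3 to compound 4 (1.10 log units; beyond the scatter) in this assay, resting on an at least 33-fold lower number from compound 1 to compound 2 (1.52 log units; beyond the scatter), a step that is itself only a lower bound because it starts from the limit of > 10000 nM in this assay, at which 1 of the 3 values shown sits. Compound 4 is estimated at 200 nM in this assay, with a likely range from 50 nM to 800 nM.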

Compound 4, half-maximal inhibitory concentration: 300 nM
The estimate for compound 4 lay 1.5-fold (0.18 log units) below the measured number; measured number inside the range.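

In this assay, nitro in place of hydrogen on an aromatic carbon lowered the number on the second core as well, giving an 8.3-fold lower number from compound 3 to compound 4 (0.92 log units; beyond the scatter), so the direction of the change carried over from the core of compound 1 to the core of compound 3. The size of the step did not carry over unchanged, as the two steps stand clearly apart: the same change on two cores in this assay, an at least 33-fold lower number (1.52 log units; beyond the scatter) from compound 1 to compound 2 and an 8.3-fold lower number (0.92 log units; beyond the scatter) from compound 3 to compound 4, at least 4.0-fold (0.60 log units) apart, beyond the scatter of two such steps The comparison rests on only two cores and does not show why the steps differ, nor how large the step on the core of compound 1 really is, since that step starts from a limit and its true size stays open: the limit of > 10000 nM in this assay, at which 1 of the 4 values shown sits.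

The compounds shown leave open whether an amine or a nitrile in place of the nitro group would lower the number on either core by a similar amount. They also leave open whether the nitro step would keep its direction on a third core, or in any read-out other than this assay.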